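A few compounds are considered here, and "the series" means these few. Any claim that something is new, unique, unknown or untested is made for them only; others in the source may bear on it.

Working notes on the series. In an ADME assay on cells (Peritoneal macrophage, Mus musculus, strain Balb/c) for cytotoxicity, read by resazurin assay, with a stated time of 72 h (on this read-out higher numbers stand for lower toxicity in this test and lower numbers for higher toxicity in this test), compound 1 `CCC1(CC)CC(S(=O)(=O)c2ccc(F)cc2)=C(c2ccc(/C(N)=N/O)cc2)O1` gives 91400 nM and compound 2 `CC1(Cc2cc(C(F)(F)F)cc(C(F)(F)F)c2)CC(S(=O)(=O)c2ccc(F)cc2)=C(c2ccc(/C(N)=N/O)cc2)O1` gives 43100 nM. Compound 3 `COc1ccc(CC2(C)CC(S(=O)(=O)c3ccc(F)cc3)=C(c3ccc(/C(N)=N/O)cc3)O2)cc1` reaches only a limit of this assay, > 100000 nM, so no number is known for it. Within the data shown here, compound 3 thus sits at the limit of > 100000 nM in this assay, at which 1 of the 3 values shown sits, with no measured step leading off it. Compound 4 `CC1(Cc2ccccc2Br)CC(S(=O)(=O)c2ccc(F)cc2)=C(c2ccc(/C(N)=N/O)cc2)O1` is not yet measured in this assay. The change is 2-bromophenyl in place of 4-methoxyphenyl on a saturated chain carbon bound to a saturated ring carbon. Among the measured compounds shown here, compound 2 carries the only other benzyl group on that chain carbon and gives a number rather than a limit. On that basis the expected step is an at least 1.4-fold lower number from compound 3 to compound 4 (0.15 log units; that floor lies within the scatter) and is estimated to be modest in size or none beyond the scatter. Compound 4 is expected near 70000 nM, within 30000 nM to 150000 nM.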

Compound 4, half-maximal cytotoxic concentration: 109000 nM
For compound 4 the middle estimate is 1.6-fold (0.19 log units) below the measured one; the measured number falls inside the stated range.
By their numbers in this assay, from the lowest: compound 2; then compounds 1 and 4 (each within the scatter of the next).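

No step can be read from compound 3 to compound 4 in this assay, because compound 3 gives only a limit: the limit of > 100000 nM in this assay, at which 1 of the 4 values shown sits.

The compounds shown leave open whether 2-bromophenyl in place of 4-methoxyphenyl changes the number in this assay at all.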